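Shortening a Hydroxamic Acid Linker by One Carbon

The source may hold more compounds than are shown below. What is called first, only, known or untested is meant among the compounds shown, and "the series" means these compounds.

Three compounds sharing one core were tested in a functional assay on A549 cells (Homo sapiens) for antiproliferative activity, read by CCK-8 assay, with a stated time of 72 h; a higher number here means a weaker inhibitor, a lower number a stronger inhibitor:

Compound 1, `CCOc1cc(C(C)(C)C)ccc1C1=NC(c2ccc(Cl)cc2)C(c2ccc(Cl)cc2)N1C(=O)NCCCCCCCC(=O)Nc1ccccc1N`, gives 15200 nM.
Compound 2, `CCOc1cc(C(C)(C)C)ccc1C1=NC(c2ccc(Cl)cc2)C(c2ccc(Cl)cc2)N1C(=O)N1CCN(CCCCCC(=O)NO)CC1`, gives 2910 nM.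
Compound 3, `CCOc1cc(C(C)(C)C)ccc1C1=NC(c2ccc(Cl)cc2)C(c2ccc(Cl)cc2)N1C(=O)NCCCCCCC(=O)Nc1ccccc1N`, gives 16000 nM.

Compound 2 carries a hydroxycarbamoyl group at the end of a chain attached to a ring amine; it holds the lowest number of the three, set apart from both compound 1 and compound 3 by margins beyond the scatter. The step to compound 4, `CCOc1cc(C(C)(C)C)ccc1C1=NC(c2ccc(Cl)cc2)C(c2ccc(Cl)cc2)N1C(=O)N1CCN(CCCCC(=O)NO)CC1`, is hydroxycarbamoyl in place of (hydroxycarbamoyl)methyl on a saturated chain carbon, four bonds along the chain from an amine nitrogen in a ring; in plain terms the chain to the hydroxycarbamoyl end is one carbon shorter.

Among the measured compounds shown here, the only measured step of a similar kind is a 1.1-fold higher number from compound 1 to compound 3 (0.02 log units; within the scatter), where the chain to a (2-aminophenyl)carbamoyl end was likewise shortened by one carbon and the number hardly moved. That step sits in a different end group and a different attachment, so it is an imperfect guide, but nothing measured suggests a large effect from one chain carbon.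

Compound 4 is therefore expected to give roughly 3400 nM, likely between 1400 nM and 8500 nM, meaning a step of a 1.2-fold higher number from compound 2 to compound 4 (0.07 log units; within the scatter) that is expected to stay within the scatter.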

Compound 4, half-maximal inhibitory concentration: 3780 nM
Beside the measured number, compound 4's estimate is 1.1-fold (0.05 log units) below it, and the stated range covers the measured number.
By their numbers in this assay, from the lowest: compounds 2 and 4 (each within the scatter of the next); then compounds 1 and 3 (each within the scatter of the next).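

In this assay, putting hydroxycarbamoyl in place of (hydroxycarbamoyl)methyl, four bonds along the chain from an amine nitrogen in a ring, gives a 1.3-fold higher number from compound 2 to compound 4 (0.11 log units; within the scatter), so the two chain lengths cannot be told apart in this assay. Until now, the only comparable shortening was at a (2-aminophenyl)carbamoyl end, a 1.1-fold higher number from compound 1 to compound 3 (0.02 log units; within the scatter); a chain ending in hydroxycarbamoyl and attached to a ring amine now shows a step within the scatter as well. No measurement is available here that could explain this result.

The compounds shown leave open how far this chain can change before the number moves beyond the scatter, as a longer chain or a 2-(hydroxycarbamoyl)ethyl chain might show. They also leave open what a carboxylic acid at the chain end would give in place of hydroxycarbamoyl.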